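The source may hold more compounds than are shown below. What is called first, only, known or untested is meant among the compounds shown, and "the series" means these compounds.

Compound 2 `CCCn1c(=O)[nH]c2nc(-c3ccc(S(=O)(=O)N4CCN(Cc5cccc(Br)c5)CC4)cc3)[nH]c2c1=O` holds the only number shown in an assay on CHO cells for displacement of a labelled ligand from adenosine receptor A1 (Mus musculus), read by scintillation counting, with a stated time of 90 min, in the presence of a further agent that is not named here; on this read-out lower numbers stand for stronger inhibition and higher numbers for weaker inhibition: compound 2 gives 107 nM. Compound 1 `CCCn1c(=O)[nH]c2nc(-c3ccc(S(=O)(=O)N4CCN(c5ccc(Br)cc5)CC4)cc3)[nH]c2c1=O` gives > 1000 nM, which is a limit of the assay. Among the compounds with values here, the one measured step, an at least 9.3-fold lower number from compound 1 to compound 2 (0.97 log units; beyond the scatter), moved 3-bromobenzyl onto the ring nitrogen in place of 4-bromophenyl. Compound 3 `CCCn1c(=O)[nH]c2nc(-c3ccc(S(=O)(=O)N4CCN(c5cccc(F)c5)CC4)cc3)[nH]c2c1=O` differs from compound 2 by 3-fluorophenyl in place of 3-bromobenzyl on an amine nitrogen in a ring, again placing an aryl ring directly on that nitrogen, as in compound 1. Compound 3 is therefore expected to give a higher number in this assay, about a 5.6-fold higher number from compound 2 to compound 3 (0.75 log units; beyond the scatter), with an estimate of 600 nM and a range from 200 nM to 2000 nM.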

Compound 3, inhibition constant: > 300 nM
Compound 3 was reported as a limit; the forecaster's own chance of this, stated with the estimate: 40%; the middle value is on the limit's open side.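

In this assay, a second aryl ring set directly on the ring nitrogen, here 3-fluorophenyl, also gives weaker inhibition than the 3-bromobenzyl of compound 2, with an at least 2.8-fold higher number from compound 2 to compound 3 (0.44 log units; beyond the scatter) for this change. Compound 3 stands only as a limit: the limit of > 300 nM in this assay, at which 1 of the 3 values shown sits. The step between compound 1 and compound 3 cannot be read, and the two directly attached aryl groups stay unranked.

From the compounds shown here alone, compound 2 and compound 3 differ in both the halogen and the benzyl carbon, so which of these tracks the difference remains open. A 3-fluorobenzyl or 3-bromophenyl group on that nitrogen would separate the two.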